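The compounds below may be only part of what the source reports. "The series", "measured", "known", "first", "only" and "open" are said of these compounds alone.

Of the compounds shown here, three have been measured in a physicochemical assay for solubility, with a stated time of 18 h, at pH 7.4; on this read-out lower numbers stand for lower solubility and higher numbers for higher solubility. Compound 1 `COc1cccc(CNCCCNc2ccnc3cc(Oc4ccccc4)ccc23)c1O` gives 14500 nM, which places it second highest of the three numbers. Compound 2 `FC(F)(F)c1ccc(-c2ccc3c(NCCCNCc4ccco4)ccnc3c2)cc1` gives 32000 nM, a higher number than compound 1 and beyond the scatter. Compound 3 `COc1ccc(F)cc1CNCCCNc1ccnc2cc(C3CCCCC3)ccc12` gives 4200 nM, the lowest of the three and also beyond the scatter from compound 1. No two of these compounds differ in a single place, so no step between measured compounds can be drawn from them.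

Compound 4 `COc1cccc(CNCCCNc2ccnc3cc(-c4ccc(C(C)(C)C)cc4)ccc23)c1O` has not yet been measured. It departs from compound 1 by 4-(tert-butyl)phenyl in place of phenoxy on an aromatic carbon. Nothing in the measured set reports this exact exchange, and the two compounds that carry a group other than phenoxy at that position of the core, compound 2 and compound 3, sit on opposite sides of compound 1 in this assay.

The expectation for compound 4 is therefore a downward step from compound 1, of a size beyond the scatter, with a 4.8-fold lower number from compound 1 to compound 4 (0.68 log units; beyond the scatter) as the estimated change. In this assay compound 4 is estimated at 3000 nM, with a range from 700 nM to 12000 nM.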

Compound 4, solubility: 32000 nM
For compound 4 the middle estimate is 11-fold (1.03 log units) below the measured one; measured number above the stated range.
By their numbers in this assay, from the lowest: compound 3; then compound 1; then compounds 2 and 4 (each within the scatter of the next).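

For the compounds shown here, at the aromatic carbon of the shared core, in this assay, putting 4-(tert-butyl)phenyl in place of phenoxy gives a 2.2-fold higher number from compound 1 to compound 4 (0.34 log units; beyond the scatter), a modest upward step and the only direct reading of a change at this position so far. The exchange goes from a group of 7 heavy atoms with one oxygen to a group of 10 heavy atoms, all carbon, and the number does not fall. No measurement at hand bears on what lies behind this step.

A single step cannot separate the part played by the tert-butyl group from that of losing the ether oxygen, and a plain phenyl or a 4-methylphenyl at this carbon would pull these two changes apart. Going by these compounds, it also remains open whether the same exchange gives a similar step in compounds with a different side chain, and how a carboxylic acid or a morpholine at this aromatic carbon would read in this assay.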